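The source may hold more compounds than are shown below. What is called first, only, known or untested is meant among the compounds shown, and "the series" means these compounds.

Compound 1 `Nc1nc([SeH])nc2ncccc12`: 96600 nM
Compound 2 `[SeH]c1nc(NCc2ccccc2)c2cccnc2n1`: > 100000 nM

Of the compounds shown here, two have been measured in a functional assay on HTB-54 cells (Homo sapiens) for cytotoxicity, read by MTT assay, with a stated time of 72 h; on this read-out lower numbers stand for stronger inhibition of growth and higher numbers for weaker inhibition of growth. For the measured compounds named here, compound 1 gives 96600 nM, the only number in the set. Compound 2 reaches only a limit of the assay, > 100000 nM, which is the limit of > 100000 nM in this assay, at which 1 of the 2 values shown sits. Going by the values given here, no pair of measured compounds differs in a single place, so no measured step exists to set the scale of a change.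

Compound 3 `[SeH]c1nc([SeH])c2cccnc2n1` is not yet measured. It differs from compound 1 by one selenium atom in place of one nitrogen atom, on an aromatic carbon. Among the compounds with values here, with no measured step to draw on, the expected step is none beyond the scatter; the value of compound 3 is estimated at 90000 nM, within 30000 nM to 300000 nM, meaning an expected step of a 1.1-fold lower number from compound 1 to compound 3 (0.03 log units; within the scatter). The estimate rests only on compound 1 at 96600 nM.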

Compound 3, concentration for total growth inhibition: 7930 nM
Compound 3: middle estimate off by 11-fold (1.05 log units), on the high side, outside the stated range (below it).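

For the compounds shown here, putting one selenium atom in place of one nitrogen atom on this aromatic carbon gives a 12-fold lower number from compound 1 to compound 3 (1.09 log units; beyond the scatter) in this assay, the first measured step in the set. It shows that this position is not indifferent to what it carries: exchanging the amino group alone, with the rest of the core unchanged, shifts the read-out towards stronger inhibition of growth by more than the usual scatter. Nothing measured here accounts for the size of this step.

The compounds shown leave open whether the gain comes from selenium itself or from the loss of the amino group, and whether a thiol, a hydroxyl or a methyl group at this position would do the same. Also open, as far as these compounds go, is how much the selenium atom already present elsewhere on the core contributes to the activity of compound 3.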